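Replacing the 3-bromobenzyl of compound 3 with 2-fluorophenyl

The compounds below may be only part of what the source reports. "The series", "measured", "known", "first", "only" and "open" are said of these compounds alone.

The shared core carries a sulfonyl-linked piperazine whose distal nitrogen bears a varied group. In an assay on CHO cells for displacement of a labelled ligand from adenosine receptor A1 (Homo sapiens), read by scintillation counting, with a stated time of 90 min, in the presence of a further agent that is not named here (on this read-out higher numbers stand for weaker inhibition and lower numbers for stronger inhibition), compound 2 `CCCn1c(=O)[nH]c2nc(-c3ccc(S(=O)(=O)N4CCN(c5ccccc5)CC4)cc3)[nH]c2c1=O` gives 364 nM. For compound 1 `CCCn1c(=O)[nH]c2nc(-c3ccc(S(=O)(=O)N4CCN(c5ccccc5Cl)CC4)cc3)[nH]c2c1=O` the result in this assay is a limit, > 1000 nM, rather than a number, as noted in the limit of > 1000 nM in this assay, at which 1 of the 3 values shown sits. Compound 3 `CCCn1c(=O)[nH]c2nc(-c3ccc(S(=O)(=O)N4CCN(Cc5cccc(Br)c5)CC4)cc3)[nH]c2c1=O` gives 928 nM in this assay, the highest of the two numbers shown; the step of a 2.5-fold higher number from compound 2 to compound 3 (0.41 log units; beyond the scatter) lies beyond the scatter, whereas the step of an at least 1.0-fold lower number from compound 1 to compound 3 (0.03 log units; that floor lies within the scatter) has a floor within the scatter.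

Compound 4 `CCCn1c(=O)[nH]c2nc(-c3ccc(S(=O)(=O)N4CCN(c5ccccc5F)CC4)cc3)[nH]c2c1=O` differs from compound 3 by 2-fluorophenyl in place of 3-bromobenzyl on an amine nitrogen in a ring. For the measured compounds named here, two measured steps bear on this change. The step of a 2.5-fold higher number from compound 2 to compound 3 (0.41 log units; beyond the scatter) shows that an aryl group directly on the ring nitrogen gave a lower number than the 3-bromobenzyl, while the step of an at least 2.7-fold lower number from compound 1 to compound 2 (0.43 log units; beyond the scatter) shows that a halogen on that aryl ring moved the number upward, to the limit. The 2-fluorophenyl of compound 4 sits between those two cases, so a modest lower number from compound 3 is expected, though with the halogen-bearing compound 1 at the limit the direction is not secure. Compound 4 is therefore estimated at 550 nM in this assay, within 200 nM to 1500 nM, an expected step of a 1.7-fold lower number from compound 3 to compound 4 (0.23 log units; within the scatter).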

Compound 4, inhibition constant: > 1000 nM
Compound 4 was reported as a limit (the forecaster's own chance of this, stated with the estimate: 20%); at least 1.8-fold (0.25 log units) between middle value and limit.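

In this assay, fluoro in place of hydrogen on an aromatic carbon moves the number upward, as an at least 2.7-fold higher number from compound 2 to compound 4 (0.43 log units; beyond the scatter) shows, so the upward move seen with the chloro of compound 1 now appears with a second halogen and the unsubstituted phenyl of compound 2 remains the only aryl case with a number below the limit. The change from the 3-bromobenzyl to 2-fluorophenyl gives an at least 1.0-fold higher number from compound 3 to compound 4 (0.03 log units; that floor lies within the scatter), whose floor lies within the scatter, so these data do not place compound 4 in any order relative to compound 3. The comparison of chloro with fluoro between compound 1 and compound 4 cannot be read, as each result is a limit and not a number: the limit of > 1000 nM in this assay, at which 2 of the 4 values shown sit.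

With both halogen-bearing phenyl compounds reported only as limits, the compounds shown do not tell how far their true values lie from that limit or whether the two halogens differ at all. They also leave open whether a methoxy group or an amine on the phenyl ring would move the number as the halogens do, and where a plain benzyl on the ring nitrogen would stand relative to the 3-bromobenzyl of compound 3.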